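From Ethylsulfanyl to Butoxy on the Five-Membered Ring

This account rests on a few compounds, and the source may have more. Where it says the series, first, only, none or still open, it means among the compounds named here.

Of the compounds shown here, three have been measured in a functional assay on MV4-11 cells (Homo sapiens) for inhibition, read by resazurin assay, with a stated time of 72 h; on this read-out lower numbers stand for stronger inhibition of growth and higher numbers for weaker inhibition of growth. Compound 1 `COc1ccc(Nc2nccc(-c3cn(C4CCCC4)c4ccccc34)n2)c(OC)c1` gives 1740 nM in this assay. Compound 3 `Oc1ccccc1Nc1nccc(-c2c[nH]c3ccccc23)n1` gives 570 nM. Compound 2 `CCSc1nc(C)c(-c2ccnc(Nc3ccc(OC)cc3OC)n2)s1` gives 32400 nM, the highest of the three numbers, so it inhibits growth least strongly; its nearest neighbour is compound 1 and its furthest neighbour is compound 3, and both gaps lie beyond the usual scatter.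

Compound 4 `CCCCOc1nc(C)c(-c2ccnc(Nc3ccc(OC)cc3OC)n2)s1` has not yet been measured in this assay. It differs from compound 2 in one place: butoxy in place of ethylsulfanyl on an aromatic carbon. Going by the values given here, no step between two measured compounds of this kind is available, so the expectation rests only on compound 2 and on the change itself, which exchanges one small chain for another on the five-membered aromatic ring.

Compound 4 is expected to stay close to compound 2, with a step of a 1.3-fold lower number from compound 2 to compound 4 (0.11 log units; within the scatter) that is likely within the scatter or only slightly beyond it, in either direction. The estimate for compound 4 in this assay is 25000 nM, within a range from 8000 nM to 80000 nM.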

Compound 4, concentration for 50% growth inhibition: 7860 nM
Beside the measured number, compound 4's estimate is 3.2-fold (0.50 log units) above it; the measured number lies below the stated range.
By their numbers in this assay, from the lowest: compound 3; then compound 1; then compound 4; then compound 2.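

In this assay, the place on the five-membered aromatic ring, next to the ring nitrogen and next to the ring sulfur, responds to a change of substituent: butoxy in place of ethylsulfanyl gives a 4.1-fold lower number from compound 2 to compound 4 (0.62 log units; beyond the scatter), a modest step but the first one seen here. It also shows that this place accepts the larger butoxy chain with no loss of growth inhibition, although the atom attached to the ring and the length of the chain change together. No supporting measurement bears on why the number moves.

As far as these compounds go, whether the step follows the oxygen or the longer chain stays open, and an ethoxy or a butylsulfanyl group at this place would separate the two. From the compounds shown here alone, how an amine or a still longer chain would behave here also remains open.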